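Benzyl for tert-Butyl on Two Related Cores

The source may report more compounds than this note shows. Statements on the series, on what has been measured and on what is new or still open speak of the compounds shown alone.

Measured so far:
compound 1, `CC1=C(C(=O)OC(C)(C)C)C(c2ccoc2)NC(=S)N1`, in an assay on membranes from HeLa cells for displacement of a labelled ligand from adenosine receptor A3 (Homo sapiens), read by scintillation counting, with a stated time of 180 min, tested at 1 uM; on this read-out lower numbers stand for less inhibition and higher numbers for more inhibition at the one concentration tested (going by the name of the read-out): 19%
compound 2, `CC1=C(C(=O)OCc2ccccc2)C(c2ccoc2)NC(=S)N1`, in this assay: 20%
compound 3, `CC1=C(C(=O)OC(C)(C)C)C(c2ccco2)NC(=O)N1C`, in this assay: 54%

Compound 2 differs from compound 1 by benzyl in place of tert-butyl on an oxygen next to a carbonyl group, and this change gave a number 1 percentage points higher from compound 1 to compound 2 (within the scatter). Compound 3 sits on a different core; how its core differs from that of compound 1 is not broken down here, and in this assay compound 3 stands above both, with compound 2 and compound 1 beyond the scatter below it.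

Compound 4, `CC1=C(C(=O)OCc2ccccc2)C(c2ccco2)NC(=O)N1C`, has not yet been measured. It differs from compound 3 by benzyl in place of tert-butyl on an oxygen next to a carbonyl group, the same change as from compound 1 to compound 2, at the same place. Since that earlier change stayed within the scatter, a step of about a number 1 percentage points higher from compound 3 to compound 4 (within the scatter) is expected for compound 4, because compound 3 already gives 54%. Compound 4 is estimated at 55%, between 40% and 70%.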

Compound 4, a percentage reported as inhibition, at one concentration (the size of the read-out at that concentration, not a potency): 11%
Compound 4: middle estimate off by 44 percentage points, on the high side; the whole stated range lies above it.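

In this assay, the step from tert-butyl to benzyl on an oxygen next to a carbonyl group gave a number 43 percentage points lower from compound 3 to compound 4 (beyond the scatter), so the result of this change on the core of compound 1 did not carry over to the core of compound 3: the same change on two cores in this assay, a number 1 percentage points higher (within the scatter) from compound 1 to compound 2 and a number 43 percentage points lower (beyond the scatter) from compound 3 to compound 4, 44 percentage points apart, beyond the scatter of two such steps

The change therefore cannot be assumed to act alike on both cores in this series. With only these two pairs, and with cores that are not separated here into single differences, the data do not show which feature of the cores goes with the divergence, or how the change would behave on any further core.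

The compounds shown leave open how a methyl or an ethyl on that same oxygen would read on either core. They also leave open whether a longer chain there would follow tert-butyl or benzyl.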